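Swapping Tert-Butyl for Cyclohexyl: Expected Cytotoxicity

This account rests on a few compounds, and the source may have more. Where it says the series, first, only, none or still open, it means among the compounds named here.

The two measured compounds share one core and differ in the chain attached to the aromatic nitrogen. In an ADME assay on Huh-7 cells (Homo sapiens) for cytotoxicity, with a stated time of 72 h (on this read-out higher numbers stand for lower toxicity in this test and lower numbers for higher toxicity in this test), compound 1, `CC(C)CCn1nc(CC2CCC2)c(O)c(C2=NS(=O)(=O)c3cc(NS(C)(=O)=O)ccc3N2)c1=O`, gives only a limit of the assay, > 33000 nM. Compound 2, `CC(C)(C)CCn1nc(-c2cccs2)c(O)c(C2=NS(=O)(=O)c3cc(NS(C)(=O)=O)ccc3N2)c1=O`, likewise gives only a limit in this assay, namely > 1000 nM. Within the data shown here, neither figure is a true number, so compound 2 stands at a limit rather than at a measured point, and no step between measured compounds can be drawn from these data.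

Compound 3, `CS(=O)(=O)Nc1ccc2c(c1)S(=O)(=O)N=C(c1c(O)c(-c3cccs3)nn(CCC3CCCCC3)c1=O)N2`, arises from compound 2 by a single change: cyclohexyl in place of tert-butyl on a saturated chain carbon, two bonds along the chain from an aromatic nitrogen. Among the measured compounds shown here, with no measured step to lean on, the expected step in this assay from compound 2 to compound 3 is none beyond the usual scatter, and the assay may again report only a limit. The estimate for compound 3 is 33000 nM, within 10000 nM to 100000 nM, corresponding to a step that the limit leaves unreadable from compound 2 to compound 3.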

Compound 3, half-maximal cytotoxic concentration: > 17000 nM
Compound 3: a limit, no number (the forecaster's own chance of this, stated with the estimate: 70%); the middle value lies beyond the limit too.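

Compound 2 and compound 3 each give only a limit rather than a number, so no step can be read for cyclohexyl in place of tert-butyl. Still open, on these data alone, is the concentration at which these compounds harm the cells, and whether this swap changes it.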